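Selenium benzyl for methylsulfanyl on two quinoline acyl-imide cores

A few compounds are considered here, and "the series" means these few. Any claim that something is new, unique, unknown or untested is made for them only; others in the source may bear on it.

The study concerns four compounds built on two related cores. Compound 2 `CS/C(=N\C(=O)c1cc(-c2ccccc2)nc2ccccc12)NC(=O)c1cc(-c2ccccc2)nc2ccccc12` and compound 1 `O=C(/N=C(/NC(=O)c1cc(-c2ccccc2)nc2ccccc12)[Se]Cc1ccccc1)c1cc(-c2ccccc2)nc2ccccc12` share one core; compound 3 `CS/C(=N\C(=O)c1cnc2ccccc2c1)NC(=O)c1cnc2ccccc2c1` and the as yet unmeasured compound 4 `O=C(/N=C(/NC(=O)c1cnc2ccccc2c1)[Se]Cc1ccccc1)c1cnc2ccccc2c1` share another. How the two cores differ is not broken down here. In an ADME assay on MCF-10A cells (Homo sapiens) for cytotoxicity, read by MTT assay, with a stated time of 72 h (on this read-out lower numbers stand for stronger inhibition of growth and higher numbers for weaker inhibition of growth), compound 2 gives 540 nM, compound 1 gives 45600 nM and compound 3 gives 42200 nM. Between compound 2 and compound 1 the change is a group of 8 heavy atoms (7 carbon, 1 selenium; one six-membered aromatic ring of carbon only) in place of a group of 2 heavy atoms (1 carbon, 1 sulfur; no ring), on a carbon with a double bond to nitrogen, and it produced an 84-fold higher number from compound 2 to compound 1 (1.93 log units; beyond the scatter). The same change, (a group of 8 heavy atoms (7 carbon, 1 selenium; one six-membered aromatic ring of carbon only) in place of a group of 2 heavy atoms (1 carbon, 1 sulfur; no ring), on a carbon with a double bond to nitrogen), takes compound 3 to compound 4, at the same place on the second core. Compound 3 already stands close to compound 1, and compound 3 sits far from compound 2 on this read-out. Because the earlier step was an 84-fold higher number from compound 2 to compound 1 (1.93 log units; beyond the scatter), a step of similar direction is expected from compound 3 to compound 4, namely a 5.9-fold higher number from compound 3 to compound 4 (0.77 log units; beyond the scatter), though with wide uncertainty since it rests on a single precedent and the starting number is already high. Compound 4 is therefore estimated at 250000 nM, between 60000 nM and 2000000 nM, with a real chance that only a limit is reported.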

Compound 4, concentration for total growth inhibition: > 100000 nM
Compound 4: no number, only a limit (the forecaster's own chance of this, stated with the estimate: 60%); the middle value is on the limit's open side.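

In this assay compound 4 gives > 100000 nM, which is a limit of the assay and not a number. Putting the selenium group with its six-membered aromatic ring in place of methylsulfanyl, on the same carbon with a double bond to nitrogen, gives an at least 2.3-fold higher number from compound 3 to compound 4 (0.37 log units; beyond the scatter), so on these two pairs the direction of the change carries over from one core to the other. The size of the change does not become comparable, and the two pairs do not show whether the second core responds as strongly as the first: the same change on two cores in this assay, an 84-fold higher number (1.93 log units; beyond the scatter) from compound 2 to compound 1 and an at least 2.3-fold higher number (0.37 log units; beyond the scatter) from compound 3 to compound 4; the limit leaves it open whether they differ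

The compounds shown also leave open how much of the step belongs to the selenium and how much to the benzyl part, as the two enter together in both pairs. A benzyl group on sulfur or a methyl group on selenium, on either core, would separate the two parts of the change.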